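This account rests on a few compounds, and the source may have more. Where it says the series, first, only, none or still open, it means among the compounds named here.

Measured so far in a functional assay on A549 cells (Homo sapiens) for cytotoxicity; a higher number here means that more compound is needed for the effect, a lower number that less compound is needed:
- Compound 1 `COc1cc(/C=C/c2ccc(C(C)(C)C)cc2)cc(OC)c1OC`: > 25 uM (a limit, not a number)
- Compound 2 `CCCOc1ccc(/C=C\c2cc(OC)c(OC)c(OC)c2)cc1`: 3.9 uM

Only one of these two results is an actual number. Compound 2 gives 3.9 uM, so it is the only firm reference point in this assay. Compound 1 gives > 25 uM, which is a limit of the assay.

The next compound to be tested is compound 3 `CCCOc1ccc(/C=C/c2cc(OC)c(OC)c(OC)c2)cc1`. The change from compound 2 is as small as a change can be: the two compounds have the same atoms and bonds and differ only in configuration as drawn: 1 of 1 stereo elements differ; a double bond is drawn Z in compound 2 and E in compound 3. The atoms and bonds stay the same, but a double bond drawn Z in compound 2 is drawn E in compound 3.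

For the measured compounds named here, no measured pair yet shows what such a switch does, so this forecast is uncertain. Compound 2, at 3.9 uM, has the Z arrangement that is being given up, and a loss of potency beyond the usual scatter is expected, meaning a higher number. The expected change is a 5.1-fold higher number from compound 2 to compound 3 (0.71 log units; beyond the scatter). For compound 3 the estimated value is 20 uM, with an expected range of 7 uM to 50 uM.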

Compound 3, concentration for half-maximal effect: 9.2 uM
The estimate for compound 3 lay 2.2-fold (0.34 log units) above the measured number, within the range that was stated.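

In this assay, for the compounds shown here, the step of a 2.4-fold higher number from compound 2 to compound 3 (0.37 log units; beyond the scatter) is the first direct reading of what this double bond does, and it shows a real but modest preference for the Z form as drawn, while the E form still gives a measured value rather than falling to the limit of the assay. That gap can be assigned to the double bond alone, because nothing else separates the two compounds: the fact that compounds 2 and 3 differ only in the configuration as drawn. With the double bond drawn E in both compounds, propoxy in place of tert-butyl on an aromatic carbon gives an at least 2.7-fold lower number from compound 1 to compound 3 (0.43 log units; beyond the scatter), so propoxy is favoured over tert-butyl, but the size of this step rests on a limit and not on a number: the limit of > 25 uM in this assay, at which 1 of the 3 values shown sits.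

From the compounds shown here alone, this is a single pair, so it remains open whether the switch from Z to E would give a step of similar size with a group other than propoxy on that ring. Going by these compounds, it also remains open whether a longer chain such as butoxy, a shorter one such as ethoxy, or an amine in place of propoxy would give a lower number in this assay.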